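Thiazolyl ureas on a biaryl core: a pyrimidine swap

This account rests on a few compounds, and the source may have more. Where it says the series, first, only, none or still open, it means among the compounds named here.

Measured so far:
- compound 1, `COc1ccc(-c2cc(NC(=O)Nc3nccs3)cc(C(F)(F)F)c2)cn1`, 36200 nM
- compound 2, `O=C(Nc1cc(-c2cncnc2)cc(C(F)(F)F)c1)Nc1nccs1`, 29700 nM
- compound 3, `COc1ccc(-c2ccc(OC(F)(F)F)c(NC(=O)Nc3nccs3)c2)cn1`, 44100 nM

Three ureas have been run in a functional assay on SMMC-7721 cells (Homo sapiens) for inhibition, read by MTT assay, with a stated time of 48 h; on this read-out higher numbers stand for weaker inhibition and lower numbers for stronger inhibition. Compound 1 gives 36200 nM in this assay. Compound 2 gives 29700 nM, and the two differ only by pyrimidin-5-yl in place of 6-methoxypyridin-3-yl on an aromatic carbon, a change that made a 1.2-fold lower number from compound 1 to compound 2 (0.09 log units; within the scatter). Compound 3 gives 44100 nM; its steps to compound 1 and compound 2 are also within the scatter, so no order among the three can be read from these numbers.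

Compound 4, `O=C(Nc1nccs1)Nc1cc(-c2cncnc2)ccc1OC(F)(F)F`, has not yet been measured in this assay. Relative to compound 3 it carries pyrimidin-5-yl in place of 6-methoxypyridin-3-yl on an aromatic carbon. Within the data shown here, this is the same kind of change as the one from compound 1 to compound 2, not the same change: the place line for compound 1 reads meta to a trifluoromethyl group, while for compound 3 it reads para to a trifluoromethoxy group. How the core of compound 1 and the core of compound 3 differ beyond that is not broken down here.

Given that the same kind of change made a 1.2-fold lower number from compound 1 to compound 2 (0.09 log units; within the scatter), compound 4 is expected to sit close to compound 3, with an estimated step of a 1.2-fold lower number from compound 3 to compound 4 (0.08 log units; within the scatter) in this assay. The estimate for compound 4 in this assay is 37000 nM, within a range from 18000 nM to 76000 nM.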

Compound 4, half-maximal inhibitory concentration: 9350 nM
Beside the measured number, compound 4's estimate is 4.0-fold (0.60 log units) above it, outside the stated range (below it).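

In this assay, placing pyrimidin-5-yl where 6-methoxypyridin-3-yl stood on the core of compound 3 gave a 4.7-fold lower number from compound 3 to compound 4 (0.67 log units; beyond the scatter), so on this core the change has a readable effect on the number. The change did not carry over at a fixed size between the two cores: the same change on two cores in this assay, a 1.2-fold lower number (0.09 log units; within the scatter) from compound 1 to compound 2 and a 4.7-fold lower number (0.67 log units; beyond the scatter) from compound 3 to compound 4, 3.9-fold (0.59 log units) apart, beyond the scatter of two such steps This shows that the size of the step depends on the core within this pair of pairs, but it gives no rule for a third core, and it does not show which feature of the core matters, since the core of compound 1 and the core of compound 3 differ both in the group carried (trifluoromethyl against trifluoromethoxy) and in where it sits.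

Going by these compounds, it remains open whether the larger step belongs to pyrimidin-5-yl itself or to the loss of 6-methoxypyridin-3-yl, and a trifluoromethyl group at the place the trifluoromethoxy group holds in compound 3 would separate the identity of that group from its place. A simple amine or a carboxylic acid on the same aromatic carbon of the core of compound 3 would show how far the step depends on an aromatic ring at that carbon at all.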